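Aryl variation on the thioether side chain

The compounds below may be only part of what the source reports. "The series", "measured", "known", "first", "only" and "open" are said of these compounds alone.

Compound 3 `OC[C@H]1OC(n2c(SCc3cccc(C(F)(F)F)c3)nc3cc(Cl)c(Cl)cc32)[C@H](O)[C@@H]1O` gives 15000 nM in a functional assay on KB cells (Homo sapiens) for inhibition; on this read-out lower numbers stand for stronger inhibition and higher numbers for weaker inhibition. Compound 2 `OC[C@H]1OC(n2c(SCc3ccc(Br)cc3)nc3cc(Cl)c(Cl)cc32)[C@H](O)[C@@H]1O` gives 20000 nM in this assay, and the pair sit within the scatter of one another: a 1.3-fold lower number from compound 2 to compound 3 (0.12 log units; within the scatter). Compound 1 `C=CCSc1nc2cc(Cl)c(Cl)cc2n1C1O[C@H](CO)[C@@H](O)[C@H]1O` gives 68000 nM, and both aryl compounds stand clear of it, with a 3.4-fold lower number from compound 1 to compound 2 (0.53 log units; beyond the scatter) and a 4.5-fold lower number from compound 1 to compound 3 (0.66 log units; beyond the scatter). Compound 4 `CC(C)(C)c1ccc(CSc2nc3cc(Cl)c(Cl)cc3n2C2O[C@H](CO)[C@@H](O)[C@H]2O)cc1` carries the change (4-(tert-butyl)phenyl in place of 3-(trifluoromethyl)phenyl on a saturated chain carbon bound to a sulfur). Within the data shown here, the only measured step that bears on exchanging one aryl group for another is the one within the scatter from compound 2 to compound 3. Accordingly no step beyond the scatter is expected in this assay, a 1.3-fold lower number from compound 3 to compound 4 (0.10 log units; within the scatter). Compound 4 is therefore estimated at 12000 nM, with a range from 5000 nM to 30000 nM.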

Compound 4, half-maximal inhibitory concentration: 50000 nM
Compound 4: the middle estimate sits 4.2-fold (0.62 log units) below what was measured; measured number outside the range, above it.
By their numbers in this assay, from the lowest: compounds 3 and 2 (each within the scatter of the next); then compounds 4 and 1 (each within the scatter of the next).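

Exchanging one aryl group for another at this position is not neutral in this assay: 4-(tert-butyl)phenyl loses ground against 3-(trifluoromethyl)phenyl (a 3.3-fold higher number from compound 3 to compound 4 (0.52 log units; beyond the scatter)), and tert-butyl loses ground against bromo on an aromatic carbon (a 2.5-fold higher number from compound 2 to compound 4 (0.40 log units; beyond the scatter)). An aryl group alone therefore does not secure a gain over vinyl, since compound 4 stays within the scatter of compound 1 (a 1.4-fold lower number from compound 1 to compound 4 (0.13 log units; within the scatter)). No supporting data explain these differences.

Going by these compounds, it remains open whether an amine or a carboxylic acid on the aryl group would shift the number. A longer chain in place of the aryl group is equally unresolved.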